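Fluoro for Bromo on the Pendant Aryl Ring

The source may hold more compounds than are shown below. What is called first, only, known or untested is meant among the compounds shown, and "the series" means these compounds.

Two members of this series share a core and differ only in the aryl group on the saturated ring carbon. Compound 1 `N#CC1=C(N)OC(c2c[nH]c3ccccc23)=C(C#N)C1c1ccccc1F` carries a 2-fluorophenyl group there, and in a functional assay on MCF7 cells (Homo sapiens) for cytotoxicity, read by MTT assay, with a stated time of 24 h (on this read-out lower numbers stand for stronger inhibition of growth and higher numbers for weaker inhibition of growth), compound 1 gives 48200 nM. Compound 2 `N#CC1=C(N)OC(c2c[nH]c3ccccc23)=C(C#N)C1c1ccc(Br)cc1` carries a 4-bromophenyl group instead, and in this assay compound 2 gives 48100 nM. The step of a 1.0-fold lower number from compound 1 to compound 2 (0.00 log units; within the scatter) shows that this exchange left the read-out flat, so compound 2 and compound 1 stand at the same level within the scatter.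

Compound 3 `N#CC1=C(N)OC(c2c[nH]c3ccccc23)=C(C#N)C1c1ccc(F)cc1` is the next variation: fluoro in place of bromo on an aromatic carbon. Going by the values given here, the only measured step that bears on it, a 1.0-fold lower number from compound 1 to compound 2 (0.00 log units; within the scatter), changed both the halogen and its position on the ring without moving the number, which suggests that the aryl halogen is not a sensitive point in this assay. Among the compounds with values here, no measured pair isolates a fluoro-for-bromo swap at this position, so the expectation rests on that single flat step. Compound 3 is therefore expected to sit close to compound 2, with a step of a 1.0-fold lower number from compound 2 to compound 3 (0.00 log units; within the scatter) that stays within the scatter. Compound 3 is estimated at 48000 nM, with a range from 20000 nM to 120000 nM.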

Compound 3, concentration for total growth inhibition: 52400 nM
Estimate against measurement, compound 3: 1.1-fold (0.04 log units) below; low and high end bracket the measured number.
By their numbers in this assay, from the lowest: compounds 2, 1 and 3 (each within the scatter of the next).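

In this assay, the step of a 1.1-fold higher number from compound 2 to compound 3 (0.04 log units; within the scatter) isolates the halogen, since the exchange of 4-bromophenyl for 4-fluorophenyl keeps its place on the ring unchanged. The step of a 1.1-fold higher number from compound 1 to compound 3 (0.04 log units; within the scatter) isolates the place, since both compounds carry a fluoro and only 2-fluorophenyl gives way to 4-fluorophenyl. The earlier step had changed halogen and place together, whereas these two steps read each change alone and show that neither moves the number beyond the scatter, so all three compounds stand at one level on this read-out; nothing available explains that flatness.

The compounds shown carry only fluoro and bromo on the phenyl group, so they leave open whether a methoxy, a hydroxyl or an amine there would separate from this level, or whether a pyridine in place of the phenyl ring would do so. They also leave open whether the same level would hold with the nitrile or amino groups of the shared core exchanged, for instance a nitrile replaced by a carboxylic acid.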